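Ring-nitrogen demethylation in the propanamide series

The source may report more compounds than this note shows. Statements on the series, on what has been measured and on what is new or still open speak of the compounds shown alone.

Compound 1 `CCC(=O)NCC1CCc2c(OC)cccc2N1C` is the reference point. In an assay on CHO cells for displacement of a labelled ligand from melatonin receptor type 1A (Homo sapiens), with a stated time of 120 min (on this read-out higher numbers stand for weaker inhibition and lower numbers for stronger inhibition), compound 1 gives 0.03 nM, the lowest of the three numbers recorded. Among the compounds with values here, compound 2 `CCNC(=O)NCC1CCc2c(OC)cccc2N1C` gives 5 nM in this assay, and the one single-site step, a 170-fold higher number from compound 1 to compound 2 (2.22 log units; beyond the scatter), concerns the carbonyl substituent, not the ring nitrogen. Compound 3 `CCNC(=S)NCC1CCc2ccccc2N1` gives 305 nM; it differs from compound 2 in several places at once, so only its value stands beside the others. Compound 4 `CCC(=O)NCC1CCc2c(cccc2OC)N1` carries the change (hydrogen in place of methyl on a nitrogen on an aromatic ring in a ring). Within the data shown here, no measured single step covers this change, so the expectation rests on compound 1 alone, with a modest weakening allowed for. For compound 4 the estimate is a 10-fold higher number from compound 1 to compound 4 (1.00 log units; beyond the scatter), giving 0.3 nM, within 0.03 nM to 3 nM.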

Compound 4, inhibition constant: 57 nM
Compound 4: middle estimate off by 190-fold (2.28 log units), on the low side; the measured number lies above the stated range.
By their numbers in this assay, from the lowest: compound 1; then compound 2; then compound 4; then compound 3.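

In this assay, the methyl on the nitrogen on an aromatic ring proves to matter greatly: hydrogen in its place gives a 1900-fold higher number from compound 1 to compound 4 (3.28 log units; beyond the scatter). Within the data shown here, this is the first measured change at this position, and it shows that the loss of a single heavy atom there is enough to weaken inhibition strongly in the propanamide series. No measured data on hand account for the size of this step.

Open, on these data alone, is how a propyl chain or an acetyl group on this nitrogen would compare with methyl and hydrogen. Also open, as far as these compounds go, is whether the same step would appear with the ethylamino carbonyl of compound 2.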